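The compounds below may be only part of what the source reports. "The series", "measured", "known", "first", "only" and "open" are said of these compounds alone.

Measured compounds:
Compound 1, `O=C1NC=C(C(=O)NCCCN2CCC(c3ccc(F)cc3)CC2)[C@@H](c2ccc(F)c(F)c2)N1`: in an in vivo ADME assay on the whole organism (Rattus norvegicus) for pharmacokinetics (a higher number here means that a larger share of the oral dose reaches the circulation, a lower number that a smaller share of the oral dose reaches the circulation), compound 1 gives 0%.
Compound 2, `CC1=C(C(=O)NCCCN2CCC(c3ccc(F)cc3)CC2)[C@@H](c2ccc(F)c(F)c2)NC(=O)N1`: the value of compound 2 in this assay is a limit of the assay, < 6%.
Compound 3, `CC1=C(C(=O)NCCCN2CCC(c3ccc(F)cc3C#N)CC2)[C@@H](c2ccc(F)c(F)c2)NC(=O)N1C`: in this assay compound 3 gives 15%.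

Compound 4, `CN1C=C(C(=O)NCCCN2CCC(c3ccc(F)cc3C#N)CC2)[C@@H](c2ccc(F)c(F)c2)NC1=O`, is not yet measured. Compound 4 differs from compound 3 by hydrogen in place of methyl on a double-bonded ring carbon. The same kind of change separates compound 2 from compound 1, (hydrogen in place of methyl on a double-bonded ring carbon), though the surroundings differ: in compound 3 the place is also next to the ring atom that bears a methyl group. The measured step that the limit leaves unreadable from compound 2 to compound 1 cannot be sized because of the limit of < 6% in this assay, at which 1 of the 3 values shown sits. How the core of compound 3 differs from that of compound 2 is not broken down here. For compound 4 the step of a number 7 percentage points lower from compound 3 to compound 4 (within the scatter) is expected to be a modest fall. That expectation rests on compound 3 with 15% and on the direction suggested by a step that the limit leaves unreadable from compound 2 to compound 1. Compound 4 is estimated at 8%.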

Compound 4, oral bioavailability: 0%
The estimate for compound 4 lay 8 percentage points above the measured number; the range from low to high includes it.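

In this assay, hydrogen in place of methyl on a double-bonded ring carbon gives a number 15 percentage points lower from compound 3 to compound 4 (beyond the scatter). Compound 2 stands at < 6%, which is a limit and not a number, so the same change from compound 2 to compound 1 cannot be read: the limit of < 6% in this assay, at which 1 of the 4 values shown sits. The series therefore offers one readable step for this change, on the core of compound 3, and does not show whether a step of that size carries over to the core of compound 2.

The compounds shown leave open how an ethyl group, a longer alkyl chain or an amine on that double-bonded ring carbon would read in this assay. They also leave open whether any such group would match the methyl group of compound 3.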